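The compounds below may be only part of what the source reports. "The series", "measured", "known", "first", "only" and "open" are said of these compounds alone.

Measured in an ADME assay on J744 cells (Mus musculus) for cytotoxicity, read by MTT assay, with a stated time of 48 h; a lower number here means a stronger inhibitor, a higher number a weaker inhibitor:
- compound 1 `Cc1nc2ccccn2c1C(=O)N/N=C/c1no[n+]([O-])c1C`: > 400000 nM (a limit)
- compound 2 `Cc1c(/C=N/NC(=O)c2cccnc2)no[n+]1[O-]`: > 400000 nM (a limit)
- compound 3 `Cc1[nH]cnc1C(=O)N/N=C/c1ccc2no[n+]([O-])c2c1`: 38000 nM

Compound 2 has no number, only a limit of this assay, namely > 400000 nM. Compound 4 `Cc1[nH]cnc1C(=O)N/N=C/c1no[n+]([O-])c1C` keeps the rest of compound 2 and changes one group: 5-methyl-1H-imidazol-4-yl in place of pyridin-3-yl on a carbonyl carbon. In words, 5-methyl-1H-imidazol-4-yl stands in place of pyridin-3-yl on a carbonyl carbon. Among the compounds with values here, no step between measured compounds is available. Compound 1 also returns only a limit, > 400000 nM. Within the data shown here, the same 5-methyl-1H-imidazol-4-yl group is present in compound 3, which gives 38000 nM, but the other end of that molecule is not the one in compound 4.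

The expected change is a number no higher from compound 2 to compound 4 (the limit leaves the size open), which means none beyond the scatter, and any real movement is expected toward a lower number. This expectation rests mainly on (the limit of > 400000 nM in this assay, at which 2 of the 3 values shown sit). For compound 4 the estimated value is 400000 nM, with an expected range from 150000 nM to 800000 nM.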

Compound 4, half-maximal inhibitory concentration: > 400000 nM
Compound 4: a limit, no number; the forecaster's own chance of this, stated with the estimate: 65%; the middle value lies on the limit itself.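

Compound 4 gives > 400000 nM in this assay, a limit and not a number, and compound 2 also stands at a limit, so no step can be read between them. The compounds shown leave open whether 5-methyl-1H-imidazol-4-yl in place of pyridin-3-yl on a carbonyl carbon changes the result at all.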